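The source may report more compounds than this note shows. Statements on the series, on what has been measured and on what is new or still open speak of the compounds shown alone.

Of the compounds shown here, two on the shared core have been measured so far: compound 1 `Nc1nc2c(c(-c3ccoc3)cn2[C@@H]2O[C@H](CO)[C@@H](O)[C@H]2O)c(=O)[nH]1`, which carries furan-3-yl, and compound 2 `Nc1nc2c(c(-c3ccsc3)cn2[C@@H]2O[C@H](CO)[C@@H](O)[C@H]2O)c(=O)[nH]1`, which carries thiophen-3-yl. In a functional assay on HepG2 cells (Homo sapiens) for antiproliferative activity, read by XTT assay, with a stated time of 72 h (a lower number here means a stronger inhibitor, a higher number a weaker inhibitor), compound 1 gives > 20000 nM, which is a limit of the assay and not a number. In this assay compound 2 gives > 20000 nM, which is again a limit and not a number. Compound 2 therefore has no exact standing, and the record so far is the limit of > 20000 nM in this assay, at which 2 of the 2 values shown sit. The next compound, compound 3 `Nc1nc2c(c(-c3ccccc3)cn2[C@@H]2O[C@H](CO)[C@@H](O)[C@H]2O)c(=O)[nH]1`, differs from compound 2 in one place: phenyl in place of thiophen-3-yl on an aromatic carbon. This puts phenyl in place of thiophen-3-yl on an aromatic carbon. For the measured compounds named here, the only measured step that bears on this change is a step that the two limits leave unreadable from compound 1 to compound 2, and it offers no size to carry forward. Compound 3 is therefore expected to stay with compound 2 at the limit because of the limit of > 20000 nM in this assay, at which 2 of the 2 values shown sit. The estimated step is a step that the limit leaves unreadable from compound 2 to compound 3, with no change beyond the scatter expected in either direction. For compound 3 the expected value is 25000 nM, within an estimated range from 12000 nM to 50000 nM.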

Compound 3, half-maximal inhibitory concentration: > 20000 nM
Compound 3 was reported as a limit; the forecaster's own chance of this, stated with the estimate: 90%; the middle value lies beyond the limit too.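

No new step can be read between compound 3 and either compound 1 or compound 2 in this assay, where each value is a limit and not a number: the limit of > 20000 nM in this assay, at which 3 of the 3 values shown sit.

The compounds shown leave open how furan-3-yl, thiophen-3-yl and phenyl rank against one another, and whether any group at this place on the shared core gives an exact value in this assay.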